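Bromo to chloro in a small cytotoxicity series

The source may hold more compounds than are shown below. What is called first, only, known or untested is meant among the compounds shown, and "the series" means these compounds.

Compound 1 `FC(F)(F)c1ccc(NCc2cn(-c3ccccc3)nc2-c2ccc(Br)cc2)cc1`: 46000 nM
Compound 2 `Cc1ccc(NCc2cn(-c3ccccc3)nc2-c2ccc(C)cc2)cc1`: > 100000 nM

For the measured compounds named here, in an ADME assay on MDBK cells (Bos taurus) for cytotoxicity, read by MTT assay, with a stated time of 72 h (a higher number here means that more compound is tolerated, a lower number that less compound is tolerated), compound 1 gives 46000 nM, the only true number so far. The reading for compound 2 is > 100000 nM, which is a limit of the assay and not a number.

Compound 3 `FC(F)(F)c1ccc(NCc2cn(-c3ccccc3)nc2-c2ccc(Cl)cc2)cc1` is still to be measured. It keeps the core of compound 1 and carries chloro in place of bromo on an aromatic carbon, para to a large group: chloro in place of bromo on an aromatic carbon. Going by the values given here, no measured pair isolates this change. The expectation therefore starts from compound 1 at 46000 nM, with no shift beyond the usual scatter foreseen in this assay. The expected 1.1-fold higher number from compound 1 to compound 3 (0.04 log units; within the scatter) is small and has no firm direction. For compound 3 the estimated value is 50000 nM, with an expected range of 24000 nM to 100000 nM.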

Compound 3, half-maximal cytotoxic concentration: 31000 nM
Compound 3: the middle estimate sits 1.6-fold (0.21 log units) above what was measured; the measured number falls inside the stated range.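

In this assay, for the compounds shown here, the change from 4-bromophenyl to 4-chlorophenyl provides the first comparison that differs in one place: a 1.5-fold lower number from compound 1 to compound 3 (0.17 log units; within the scatter). Going by these compounds alone, at this position, on an aromatic carbon para to a large group, exchanging bromo for chloro therefore produces no step that the assay can separate from repeat-measurement scatter, and compound 1 and compound 3 read as equivalent. Compound 2 differs from compound 1 in more than one place and its reading is a limit of the assay, not a number, so it adds no comparison here: the limit of > 100000 nM in this assay, at which 1 of the 3 values shown sits.

Still open, going by these compounds, is whether a non-halogen group at this position, such as an amine or a carboxylic acid, would move the number beyond the scatter. Also open, on these data alone, is how the reading would respond if a nitrile replaced the trifluoromethyl group while the 4-chlorophenyl stayed in place.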